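Methylating the Phenol Oxygen in a Urethral Agonist Series

A few compounds are considered here, and "the series" means these few. Any claim that something is new, unique, unknown or untested is made for them only; others in the source may bear on it.

Measured compounds:
Compound 1 `CC(C)S(=O)(=O)Nc1cccc2c1CCCC2c1c[nH]cn1`: 5.17
Compound 2 `O=S(=O)(Nc1cccc2c1CCCC2c1c[nH]cn1)C1CC1`: 5.25
Compound 3 `CS(=O)(=O)Nc1ccc(O)c2c1CCCC2c1c[nH]cn1`: 4.61

In a functional assay on Urethra for agonist activity at Alpha-1A adrenergic receptor (Oryctolagus cuniculus) (a higher number here means a more potent compound, by a factor of ten per unit of this negative logarithm, a lower number a less potent compound), compound 3 gives the lowest of the three numbers. Its nearest neighbour is compound 1, which lies above it by a gap beyond the scatter, and compound 2 lies above it by a slightly wider gap. Compound 4 `COc1ccc(NS(C)(=O)=O)c2c1C(c1c[nH]cn1)CCC2` differs from compound 3 in one place: methyl in place of hydrogen on an oxygen on an aromatic ring — the hydroxy becomes a methoxy.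

For the measured compounds named here, only one single-point step has been measured in this set, a number 0.08 log units higher from compound 1 to compound 2 (within the scatter), and it concerns the group on the sulfonyl sulfur, not the oxygen on the aromatic ring. Going by the values given here, no measured pair separates a hydroxy from a methoxy. Among the compounds with values here, compound 1 and compound 3 differ in two places at once, so their values show only that the compound without the hydroxy gives the higher number, without saying which change is responsible.

Within the data shown here, with no step bearing on this change, nothing supports expecting a move beyond the scatter in this assay. Compound 4 is therefore expected near 4.75, within a range from 4.2 to 5.3. The step expected is a number 0.14 log units higher from compound 3 to compound 4 (within the scatter), effectively no change beyond the scatter.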

Compound 4, negative logarithm of the half-maximal effective concentration: 4.81
For compound 4 the middle estimate is 0.06 log units below the measured one, within the range that was stated.
By their numbers in this assay, from the lowest: compounds 3 and 4 (each within the scatter of the next); then compounds 1 and 2 (each within the scatter of the next).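

In this assay, for the compounds shown here, replacing the hydrogen on the oxygen on the aromatic ring with methyl gives a number 0.20 log units higher from compound 3 to compound 4 (within the scatter), the first measured step at this position. Hydroxy and methoxy therefore cannot be told apart here: for this pair, on this core, the hydrogen on that oxygen is not required to keep the number in this assay, and the extra methyl is accommodated without a shift beyond the scatter. The data at hand offer no measurement that accounts for this outcome.

Going by these compounds, the pair covers only the smallest possible change to that oxygen, so it remains open whether a longer chain, such as ethoxy or propoxy, or an amine in place of the hydroxy would also leave the number in this assay within the scatter. On these data alone, both compounds also carry methyl on the sulfonyl sulfur, so the same hydroxy to methoxy change remains untested in this set with isopropyl or cyclopropyl on that sulfur.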